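Adding a methoxy to compound 1: effect on cell tolerance

A few compounds are considered here, and "the series" means these few. Any claim that something is new, unique, unknown or untested is made for them only; others in the source may bear on it.

Compound 1: `CC(C)=CCOc1cc(Nc2ncnc(Cl)n2)ccc1Cl`, 45000 nM
Compound 2: `COc1ncnc(Nc2ccc(Cl)c(OCC=C(C)C)c2)n1`, 18000 nM
Compound 3: `CNc1ncnc(Nc2ccc(Cl)c(OCC=C(C)C)c2)n1`, 3100 nM

These three compounds were tested in an ADME assay on MT2 cells (Homo sapiens) for cytotoxicity; a higher number here means that more compound is tolerated, a lower number that less compound is tolerated. Compound 1 stands highest of the three numbers, so it is the best tolerated. The nearest is compound 2 with a 2.5-fold lower number from compound 1 to compound 2 (0.40 log units; beyond the scatter), and the furthest is compound 3 with a 15-fold lower number from compound 1 to compound 3 (1.16 log units; beyond the scatter). Between those two, a 5.8-fold lower number from compound 2 to compound 3 (0.76 log units; beyond the scatter).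

Compound 4 is `COc1nc(Cl)nc(Nc2ccc(Cl)c(OCC=C(C)C)c2)n1`. It differs from compound 1 in one way: methoxy in place of hydrogen on an aromatic carbon. Unlike compounds 2 and 3, compound 4 keeps the chloro group of compound 1 and gains the methoxy on a different carbon of the shared core. Within the data shown here, the closest measured step is the one from compound 1 to compound 2, where a methoxy entered the same core and the tolerated concentration fell by a modest amount. Compound 3 shows that a methylamino lowers tolerance more, but no methylamino is involved here. A modest drop in this assay is therefore expected for compound 4, giving an estimated 2.0-fold lower number from compound 1 to compound 4 (0.31 log units; beyond the scatter). Compound 4 is expected to give about 22000 nM, within a range of 9000 nM to 50000 nM.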

Compound 4, half-maximal cytotoxic concentration: 26000 nM
For compound 4 the middle estimate is 1.2-fold (0.07 log units) below the measured one, within the range that was stated.
By their numbers in this assay, from the lowest: compound 3; then compounds 2, 4 and 1 (each within the scatter of the next, the first and the last beyond it).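

In this assay, methoxy on the aromatic carbon between two ring nitrogen atoms, with the chloro group kept, gives a 1.7-fold lower number from compound 1 to compound 4 (0.24 log units; within the scatter), so this position takes the methoxy with no readable change in tolerance. The earlier compounds shown here only showed what happens when a group replaces the chloro; here, the chloro stays and the new group enters on a carbon that carried hydrogen. Chloro in place of hydrogen on the methoxy-bearing core also gives only a small step, a 1.4-fold higher number from compound 2 to compound 4 (0.16 log units; within the scatter), so compound 4 cannot be told apart from either neighbor, even though a 2.5-fold lower number from compound 1 to compound 2 (0.40 log units; beyond the scatter) separates those two neighbors; the data offer no explanation for any of these steps.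

What the compounds shown leave open is whether this carbon tolerates other groups equally well, such as a longer chain like butoxy or a carboxylic acid. They also leave open whether a free amine at this carbon, with the chloro kept, would follow the methoxy of compound 4 or the lower number of compound 3.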